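The source may report more compounds than this note shows. Statements on the series, on what has been measured and on what is new or still open speak of the compounds shown alone.

Working notes on the series.

Of the compounds shown here, two of the shared core have numbers so far. Compound 1 `O=[N+]([O-])c1ccccc1-c1nc2cc(C(F)(F)F)ccc2[nH]1` carries a nitro group and in a functional assay on aorta (Rattus norvegicus, strain Wistar) for inhibition, with a stated time of 60 min (a higher number here means a larger maximal response, a lower number a smaller maximal response), compound 1 gives 93.2%. Compound 2 `COc1cc(-c2nc3cc(C(F)(F)F)ccc3[nH]2)ccc1O` carries a methoxy and a hydroxy group instead, and in this assay compound 2 gives 99.6%. Compound 1 stands at the lower of the two numbers, but the gap to compound 2 lies within the usual scatter, so the two cannot be told apart on these data. Among the measured compounds shown here, no step between measured compounds that differ in one place is available, so the series gives no measured guide to the size of a single change.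

Compound 3 `CCOc1ccccc1-c1nc2cc(C(F)(F)F)ccc2[nH]1` is the next to be measured in this assay. Relative to compound 1 the change is ethoxy in place of nitro on an aromatic carbon. For the measured compounds named here, with both known compounds near full maximal response and no measured step to go by, the step from compound 1 to compound 3 is expected to stay within the scatter, as a number 1.8 percentage points higher from compound 1 to compound 3 (within the scatter). For compound 3 the expected value in this assay is 95%, with a range from 82% to 100%.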

Compound 3, largest response reached (Emax), in percent of the reference or control that the assay uses: 91%
Beside the measured number, compound 3's estimate is 4 percentage points above it; the range from low to high includes it.
By their numbers in this assay, from the lowest: compounds 3, 1 and 2 (each within the scatter of the next).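

In this assay, among the compounds shown here, the exchange on an aromatic carbon, ortho to a large group, gives a number 2.2 percentage points lower from compound 1 to compound 3 (within the scatter), the first measured step that differs in one place. Nitro and ethoxy are equal in heavy atoms but differ in composition, one bringing nitrogen and oxygen and the other carbon and oxygen, and it also removes the double bond outside aromatic rings, yet the maximal response of the pair cannot be told apart at this position. No measurement on hand bears on why the two compounds cannot be separated, so the result stands as an observation for this single pair.

This one step does not show whether the position tolerates substitution in general or whether these two groups merely happen to give indistinguishable numbers. As far as these compounds go, whether an amine, a carboxylic acid or a longer chain such as butoxy in the same place would move the maximal response beyond the scatter remains open, as does the effect of the hydrogen-bond donor that neither nitro nor ethoxy provides.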